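From an aminophenyl to a dichlorophenyl group

The source may report more compounds than this note shows. Statements on the series, on what has been measured and on what is new or still open speak of the compounds shown alone.

Compound 1 `COC(=O)C1=C(C)N=C(C)/C(=C(\O)OC)C1c1cccc(N(C)C)c1` gives 891 nM
Compound 2 `COC(=O)C1=C(C)N=C(C)/C(=C(\O)OC)C1c1ccccc1I` gives 46.8 nM
Compound 3 `COC(=O)C1=C(C)N=C(C)/C(=C(\O)OC)C1c1cccc(N)c1` gives 2000 nM

In a functional assay (muscle tissue) with Cavia porcellus as the target (on this read-out higher numbers stand for an effect only at larger amounts of compound and lower numbers for an effect already at smaller amounts), compound 3 has the highest number of the three (2000 nM), so it needs the largest amount of compound for an effect. Compound 4 `COC(=O)C1=C(C)N=C(C)/C(=C(\O)OC)C1c1cccc(Cl)c1Cl` keeps the shared core but carries 2,3-dichlorophenyl in place of 3-aminophenyl on a saturated ring carbon. Its number is not yet known.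

For the measured compounds named here, two measured steps bear on this change. The closer one also exchanges the group on that saturated ring carbon, and it is large (a 43-fold higher number from compound 2 to compound 3 (1.63 log units; beyond the scatter)). The other, amino in place of dimethylamino on an aromatic carbon, is modest (a 2.2-fold higher number from compound 1 to compound 3 (0.35 log units; beyond the scatter)). Going by the values given here, compound 2 (46.8 nM) is the only measured compound with a halogen on its phenyl group, and no dichlorophenyl compound has been measured, so this guide is indirect. Read in reverse, the large step points to a large expected fall towards a lower number (a 67-fold lower number from compound 3 to compound 4 (1.82 log units; beyond the scatter)). The estimate for compound 4 is 30 nM (expected range 6 nM to 150 nM).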

Compound 4, half-maximal effective concentration: 19.1 nM
Compound 4: middle estimate off by 1.6-fold (0.20 log units), on the high side; low and high end bracket the measured number.
By their numbers in this assay, from the lowest: compound 4; then compound 2; then compound 1; then compound 3.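

In this assay the group on the saturated ring carbon proves able to move the number further than any earlier step did, with a 100-fold lower number from compound 3 to compound 4 (2.02 log units; beyond the scatter) when 2,3-dichlorophenyl takes the place of 3-aminophenyl. Changing one halogen-bearing phenyl group for another matters much less but still counts, with a 2.5-fold lower number from compound 2 to compound 4 (0.39 log units; beyond the scatter) when 2,3-dichlorophenyl takes the place of 2-iodophenyl. Both halogen-bearing compounds have far lower numbers than compound 3, so the low range is not tied to iodine alone.

As far as these compounds go, whether a single chlorine, a methoxy group or a nitrile on the phenyl group would reach the same low range remains open. Nothing available here explains why these groups give such different numbers.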